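Compound 3 to compound 4: methyl for chloro

The source may report more compounds than this note shows. Statements on the series, on what has been measured and on what is new or still open speak of the compounds shown alone.

In an ADME assay for permeability, using PAMPA, at pH 7.4 (on this read-out lower numbers stand for lower permeability and higher numbers for higher permeability), compound 3 (`O=C(Nc1cc(-c2nc3ccccc3s2)ccc1Cl)c1cc([N+](=O)[O-])ccc1Cl`) gives "below limit of detection" (no number reported). Compound 2 (`COc1ccc(-c2nc3ccccc3s2)cc1NC(=O)c1cc([N+](=O)[O-])ccc1Cl`) gives "below limit of detection" (no number reported) as well. Compound 1 (`Cc1ccc(-c2nc3ccccc3s2)cc1NC(=O)c1cc([N+](=O)[O-])c(N(C)C)cc1Cl`) gives < 1 10^-6 cm/s, which is a limit of the assay and not a number. None of the three therefore has a single number, and compound 3 cannot be placed in an order with the other two.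

Compound 4 (`Cc1ccc(-c2nc3ccccc3s2)cc1NC(=O)c1cc([N+](=O)[O-])ccc1Cl`) has not yet been measured. The structural change is methyl in place of chloro on an aromatic carbon, ortho to a large group and para to a 1,3-benzothiazol-2-yl group. The same methyl is present in compound 1, whose entry of < 1 10^-6 cm/s is a limit. Among the compounds with values here, no measured pair isolates this swap, so the expectation rests on limits alone. No step beyond the scatter is expected in this assay, in either direction, and a further limit is the most likely report. Should a number be reported, the estimated value for compound 4 is 0.5 10^-6 cm/s, with an expected range from 0.1 10^-6 cm/s to 1.5 10^-6 cm/s.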

Compound 4, apparent permeability: 41 10^-6 cm/s
The estimate for compound 4 lay 82-fold (1.91 log units) below the measured number, and the stated range ends below it.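

At this position, ortho to a large group and para to a 1,3-benzothiazol-2-yl group, methyl is the only group among the compounds shown that comes with a number in this assay, since compound 3 with chloro and compound 2 with methoxy carry none. Compound 1, which keeps the same methyl, also gives no number, only a limit of the assay: the limit of < 1 10^-6 cm/s in this assay, at which 1 of the 4 values shown sits.

The methyl therefore does not bring a number by itself: hydrogen in place of dimethylamino goes with an at least 41-fold higher number from compound 1 to compound 4 (1.61 log units; beyond the scatter), and that step starts from a limit, so its true size is open.

The steps from compound 3 and from compound 2 to compound 4 cannot be read, which leaves the size of the change at this position unknown, and a single number in the series gives no trend. Open too, going by these compounds, is how this position behaves with groups such as fluoro, ethyl, a primary amine or a carboxylic acid, and whether a number survives at the dimethylamino place with a smaller group such as methoxy.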